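Swapping a thiazole for a methylpyridine: expected oral exposure

A few compounds are considered here, and "the series" means these few. Any claim that something is new, unique, unknown or untested is made for them only; others in the source may bear on it.

Measured so far:
compound 1 `Cc1cn2c(-c3cn[nH]c3)cnc2c(Nc2cc(Cc3nccs3)ns2)n1`: 1540 ng.h/mL
compound 2 `Cc1cn2c(-c3cn[nH]c3)cnc2c(Nc2cc(Cc3cccnc3)ns2)n1`: "not determined" (no result reported)

Going by the values given here, in an ADME assay on the whole organism for pharmacokinetics, with Rattus norvegicus as the target, with a stated time of 6 h, at a dose of 10 mg/kg by the oral route (a lower number here means less compound in the circulation, a higher number more compound in the circulation at the dose given), compound 1 gives 1540 ng.h/mL, the only number available here, since compound 2 was tested without a reported result. Compound 3 `Cc1ccnc(Cc2cc(Nc3nc(C)cn4c(-c5cn[nH]c5)cnc34)sn2)c1` differs from compound 1 by one change: 4-methylpyridin-2-yl in place of 1,3-thiazol-2-yl on a saturated chain carbon bound to an aromatic carbon. Among the compounds with values here, no measured step on this core shows what such a change does, so a step from compound 1 to compound 3 of about the size of the scatter, in either direction, is expected: a 1.3-fold lower number from compound 1 to compound 3 (0.11 log units; within the scatter). For compound 3 in this assay the expected value is 1200 ng.h/mL, with a range from 400 ng.h/mL to 3500 ng.h/mL.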

Compound 3, area under the concentration-time curve: 1850 ng.h/mL
Compound 3: the middle estimate sits 1.5-fold (0.19 log units) below what was measured, and the stated range covers the measured number.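

Going by these compounds alone, with a 1.2-fold higher number from compound 1 to compound 3 (0.08 log units; within the scatter) in this assay as the first measured step at this position, the saturated chain carbon bound to an aromatic carbon accepts a six-membered aromatic ring as well as a five-membered one. The 4-methylpyridin-2-yl and 1,3-thiazol-2-yl compounds lie within the scatter of each other, so exposure is kept across this swap. Nothing shown gives a reason for this. The compounds shown leave open whether a non-aromatic group on that carbon, such as a morpholine or a simple amine, would fare alike.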